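The compounds below may be only part of what the source reports. "The series", "measured", "known", "first", "only" and "open" are said of these compounds alone.

The series rests on one shared core carrying two aromatic groups on a saturated chain carbon, with the remaining substituent on that carbon varied. Compound 1 `COc1cc(C(c2ccc(O)c(OC)c2)[C@H](C)[C@@H](C)CF)ccc1O` and compound 2 `COc1cc(C(c2ccc(O)c(OC)c2)[C@@H](C)[C@H](C)CF)ccc1O` are mirror images, and in a functional assay on HeLa cells (Homo sapiens) for cytotoxicity, read by WST assay, with a stated time of 48 h (on this read-out lower numbers stand for stronger inhibition and higher numbers for weaker inhibition), compound 1 gives 34000 nM while compound 2 gives 37000 nM, a pair that differs by a 1.1-fold higher number from compound 1 to compound 2 (0.04 log units; within the scatter); the two compounds are alike apart from the fact that compounds 1 and 2 differ only in the configuration as drawn. Compound 3 `COc1cc(C(c2ccc(O)c(OC)c2)[C@H](CC(C)C)C(C)C)ccc1O` stands lowest of the three numbers, giving 8200 nM in this assay, which is a 4.1-fold lower number from compound 1 to compound 3 (0.62 log units; beyond the scatter) and a 4.5-fold lower number from compound 2 to compound 3 (0.65 log units; beyond the scatter).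

Compound 4 `COc1cc(C(c2ccc(O)c(OC)c2)[C@H](C)[C@@H](C)CO)ccc1O` returns to the shorter, more polar type of substituent: 2-(hydroxymethyl)-1-methylpropyl in place of 1-isopropyl-3-methylbutyl on a saturated chain carbon bound to two aromatic carbons. Going by the values given here, the steps that bear on this change are the two modest ones from compounds 1 and 2 to compound 3, in which the 2-(fluoromethyl)-1-methylpropyl group was exchanged for 1-isopropyl-3-methylbutyl and the number fell. Compound 4 carries a 2-(hydroxymethyl)-1-methylpropyl group, which resembles the group of compounds 1 and 2 far more than that of compound 3, so a step back upward in this assay, of roughly the size seen in those two steps or somewhat larger, is expected. Compound 4 is therefore expected to give about 45000 nM in this assay, within a range of 15000 nM to 130000 nM, which corresponds to an expected 5.5-fold higher number from compound 3 to compound 4 (0.74 log units; beyond the scatter).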

Compound 4, half-maximal inhibitory concentration: > 100000 nM
Compound 4: no number, only a limit; the forecaster's own chance of this, stated with the estimate: 15%; middle value at least 2.2-fold (0.34 log units) from the limit.
By their numbers in this assay, from the lowest: compound 3; then compounds 1 and 2 (each within the scatter of the next). At a limit, above all of these: compound 4.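

Compound 4 shows that this position can also move the number sharply upward: 2-(hydroxymethyl)-1-methylpropyl in place of 1-isopropyl-3-methylbutyl on a saturated chain carbon bound to two aromatic carbons gives an at least 12-fold higher number from compound 3 to compound 4 (1.08 log units; beyond the scatter). In this assay, going by these compounds, compound 4 gives only a limit, > 100000 nM, and not a number, so the true size of each of its steps remains unknown. The earlier compounds shown here also gave no sign that the group on the far part of this substituent could matter, yet hydroxy in place of fluoro gives an at least 2.9-fold higher number from compound 1 to compound 4 (0.46 log units; beyond the scatter), and the comparison with the mirror-image partner gives an at least 2.7-fold higher number from compound 2 to compound 4 (0.43 log units; beyond the scatter), whereas inverting all stereocentres gave only a 1.1-fold higher number from compound 1 to compound 2 (0.04 log units; within the scatter).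

On these data alone, it remains open how far beyond the limit compound 4 lies, and whether an amine or a carboxylic acid in place of the hydroxy group would behave in the same way. As far as these compounds go, it is also open whether the mirror image of compound 4 would stay within the scatter of compound 4, as compound 2 does of compound 1.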